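Methyl to methoxy: a second pair in the series

This account rests on a few compounds, and the source may have more. Where it says the series, first, only, none or still open, it means among the compounds named here.

In a functional assay on HeLa cells (Homo sapiens) for inhibition, read by MTT assay, with a stated time of 48 h (a higher number here means a weaker inhibitor, a lower number a stronger inhibitor), compound 1 `Cc1ccc(-n2cc(NC(=O)c3cccc(NS(=O)(=O)c4ccccc4)c3)cn2)cc1` gives 3120 nM. Compound 2 `COc1ccc(-n2cc(NC(=O)c3cccc(NS(=O)(=O)c4ccccc4)c3)cn2)cc1` differs from it by methoxy in place of methyl on an aromatic carbon and in this assay compound 2 gives 42200 nM; the step is a 14-fold higher number from compound 1 to compound 2 (1.13 log units; beyond the scatter). Compound 3 `Cc1ccc(-n2cc(NC(=O)c3ccc(NS(=O)(=O)c4ccc(Cl)cc4)cc3)cn2)cc1` rests on a different core, and the difference between the two cores is not broken down here; in this assay compound 3 gives 8010 nM, a number standing between those of compound 1 and compound 2. Compound 4 `COc1ccc(-n2cc(NC(=O)c3ccc(NS(=O)(=O)c4ccc(Cl)cc4)cc3)cn2)cc1` is not yet measured. It differs from compound 3 by methoxy in place of methyl on an aromatic carbon, the same change as from compound 1 to compound 2, at a place described in the same words; the change appears in two pairs in all. Among the compounds with values here, because a 14-fold higher number from compound 1 to compound 2 (1.13 log units; beyond the scatter) is the only measured instance of the change and sits on another core, the expectation is held somewhat short of that size: the expected step is an 8.7-fold higher number from compound 3 to compound 4 (0.94 log units; beyond the scatter). For compound 4 in this assay the estimate is 70000 nM, expected to lie between 15000 nM and 300000 nM.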

Compound 4, half-maximal inhibitory concentration: 25200 nM
Estimate against measurement, compound 4: 2.8-fold (0.44 log units) above, and the stated range covers the measured number.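

In this assay the change from 4-methylphenyl to 4-methoxyphenyl gives a 3.1-fold higher number from compound 3 to compound 4 (0.50 log units; beyond the scatter), so the number rises on the core of compound 3 as it does on the core of compound 1. The direction of the change is therefore shared by both pairs, but its size does not carry over unchanged from one core to the other: the same change on two cores in this assay, a 14-fold higher number (1.13 log units; beyond the scatter) from compound 1 to compound 2 and a 3.1-fold higher number (0.50 log units; beyond the scatter) from compound 3 to compound 4, 4.3-fold (0.63 log units) apart, beyond the scatter of two such steps. These two pairs show only that the direction held on these two cores; they do not establish a general rule for the series, and they do not show which of the differences between the cores goes with the gap in size.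

Still open, on these data alone, is whether a core that differs from the core of compound 1 in only one place would give a step nearer the larger or the smaller size. Also open, as far as these compounds go, is how a hydroxyl, an amine or an ethoxy group on the same aromatic carbon would compare with methyl and methoxy on either core.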